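The source may report more compounds than this note shows. Statements on the series, on what has been measured and on what is new or still open speak of the compounds shown alone.

Measured in a functional assay on Jurkat cells (Homo sapiens) for cytotoxicity, read by MTT assay; on this read-out higher numbers stand for weaker inhibition and lower numbers for stronger inhibition:

Compound 1 `CCOC(=O)CCCn1cc(Br)c2cc(O)c(O)cc2c1=O`: 11000 nM
Compound 2 `CCOC(=O)CCCn1cc(C(C)=O)c2cc(OC)c(OC)cc2c1=O`: 47000 nM
Compound 3 `CCCn1c(=O)n(CCCC(=O)OCC)c(=O)c2nccnc21`: a limit of the assay, > 25000 nM

Among the two numbers reported, compound 1 gives the lowest, and compound 2 gives a higher number, a gap beyond the scatter. For compound 3 the assay reports only a limit, which is also where one of the three values sits (the limit of > 25000 nM in this assay, at which 1 of the 3 values shown sits). Compound 4 `CCOC(=O)CCCn1ccc2cc(O)c(O)cc2c1=O` keeps the core of compound 1 and differs from it in one place: hydrogen in place of bromo on an aromatic carbon. For the measured compounds named here, no measured pair shows this change, so its effect is not known from these data. Compound 4 is expected to lie somewhat higher than compound 1 in this assay, a step of a 1.8-fold higher number from compound 1 to compound 4 (0.26 log units; within the scatter), with wide uncertainty. The estimate for compound 4 is 20000 nM, between 6000 nM and 60000 nM.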

Compound 4, half-maximal inhibitory concentration: 47000 nM
Estimate against measurement, compound 4: 2.4-fold (0.37 log units) below; the measured number falls inside the stated range.
By their numbers in this assay, from the lowest: compound 1; then compounds 2 and 4 (each within the scatter of the next).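

In this assay, for the compounds shown here, the change from bromo to hydrogen on this aromatic carbon, two atoms from the ring nitrogen, gives a 4.3-fold higher number from compound 1 to compound 4 (0.63 log units; beyond the scatter) and is the first single-place comparison in the set. On the core of compound 1, the bromo group therefore goes with the lower number, by a step beyond the scatter. Nothing measured here accounts for this step.

The compounds shown leave open whether chloro, iodo or an amine on this carbon would match bromo. They also leave open whether the step would persist with methoxy groups replacing the two hydroxyl groups.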